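Turning the Amide Around on a Shared Core

A few compounds are considered here, and "the series" means these few. Any claim that something is new, unique, unknown or untested is made for them only; others in the source may bear on it.

Three compounds share one core and differ only in the group carried on a saturated ring carbon. Compound 1 `Cc1nn(-c2ncnc3nc[nH]c23)c2c1C(C(=O)Nc1ccccc1)CC(=O)N2` bears phenylcarbamoyl there, compound 2 `Cc1nn(-c2ncnc3nc[nH]c23)c2c1C(OCc1ccccc1C#N)CC(=O)N2` bears (2-cyanobenzyl)oxy, and compound 3 `Cc1nn(-c2ncnc3nc[nH]c23)c2c1C(OCCn1nccc1C)CC(=O)N2` bears a group built on a five-membered aromatic ring. In a functional assay on HEK293 cells for agonist activity at G-protein coupled receptor 39 (Homo sapiens), read by scintillation proximity assay and inositol phosphate accumulation, with a stated time of 75 min, in the presence of a further agent that is not named here (a higher number here means that more compound is needed for the effect, a lower number that less compound is needed), compound 1 gives 10 nM, compound 2 gives 8 nM, and compound 3 gives 10 nM. The three numbers sit together: a 1.3-fold lower number from compound 1 to compound 2 (0.10 log units; within the scatter), no change at the digits printed from compound 1 to compound 3 (within the scatter), and a 1.3-fold higher number from compound 2 to compound 3 (0.10 log units; within the scatter). Compound 1 thus stands level with compound 3 at the digits shown, the two together the highest of the three, and no compound here is set apart from another beyond the scatter.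

Compound 4 `Cc1nn(-c2ncnc3nc[nH]c23)c2c1C(NC(=O)c1ccccc1)CC(=O)N2` is made of the same atoms as compound 1, joined differently: benzamido in place of phenylcarbamoyl on a saturated ring carbon. Among the compounds with values here, no measured step reverses an amide in this way. The steps that do exist swap the whole group on this carbon for quite different groups, and each of them stayed within the scatter, which suggests this position tolerates variation. Compound 4 is therefore expected to give 10 nM, within a range from 4 nM to 30 nM. The step of no change at the digits printed from compound 1 to compound 4 (within the scatter) is expected to stay within the scatter.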

Compound 4, half-maximal effective concentration: 3 nM
For compound 4 the middle estimate is 3.3-fold (0.52 log units) above the measured one; the whole stated range lies above it.
By their numbers in this assay, from the lowest: compound 4; then compounds 2, 1 and 3 (each within the scatter of the next).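

Reversing the amide on the saturated ring carbon is the first change at this position to move the number in this assay beyond the scatter (a 3.3-fold lower number from compound 1 to compound 4 (0.52 log units; beyond the scatter)), although benzamido and phenylcarbamoyl have the same atoms, joined differently. Benzamido also stands apart from the other two groups on this carbon (a 3.3-fold lower number from compound 3 to compound 4 (0.52 log units; beyond the scatter); a 2.7-fold lower number from compound 2 to compound 4 (0.43 log units; beyond the scatter)), so this position is less indifferent than the earlier compounds suggested, and here how the atoms are joined matters as well as which atoms are present. Nothing presented here bears on why the reversed amide gives the lower number.

The compounds shown leave open whether the lower number would hold if a pyridine ring or a cyclohexyl group replaced the phenyl ring of benzamido. They also leave open how N-methylbenzamido, a phenylurea or a benzenesulfonamido group on this carbon would compare with benzamido.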